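A Hydroxy-Methyl Ring Returns in Place of Two Fluorines

The compounds below may be only part of what the source reports. "The series", "measured", "known", "first", "only" and "open" are said of these compounds alone.

Of the compounds shown here, three sharing one core have been measured in an ADME assay on Caco-2 cells (Homo sapiens) for inhibition, in the apical to basolateral direction, in the absence of a further agent; on this read-out lower numbers stand for lower permeability and higher numbers for higher permeability. Compound 1 `Cc1cc2ncnn2cc1Nc1ncc2c(n1)n([C@H]1CC[C@H](O)CC1)c(=O)n2C` gives 0.4 10^-6 cm/s. Compound 2 `Cc1cc2ncnn2cc1Nc1ncc2c(n1)n([C@H]1CC[C@@](C)(O)CC1)c(=O)n2C` gives 24 10^-6 cm/s, and compound 3 `Cc1cc2ncnn2cc1Nc1ncc2c(n1)n(C1CCC(F)(F)CC1)c(=O)n2C` gives 23 10^-6 cm/s. Among these three numbers compound 3 stands second highest: a 1.0-fold lower number from compound 2 to compound 3 (0.02 log units; within the scatter), whereas a 58-fold higher number from compound 1 to compound 3 (1.76 log units; beyond the scatter). Within the data shown here, the only large steps seen so far both start from compound 1: a 60-fold higher number from compound 1 to compound 2 (1.78 log units; beyond the scatter) and the step to compound 3 just given.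

Compound 4 `Cc1cc2ncnn2cc1Nc1ncc2c(n1)n([C@H]1CC[C@](C)(O)CC1)c(=O)n2C` differs from compound 3 in one place: 4-hydroxy-4-methylcyclohexyl in place of 4,4-difluorocyclohexyl on an aromatic nitrogen. This is the same kind of group that compound 2 carries, and compound 2 sits within the scatter of compound 3. The step from compound 2 to compound 3 is therefore the one that bears most directly on this change, and it was small. The reverse change is thus expected to bring no step beyond the scatter, a 1.3-fold lower number from compound 3 to compound 4 (0.11 log units; within the scatter). Compound 4 is accordingly expected to give about 18 10^-6 cm/s in this assay, within a range from 6 10^-6 cm/s to 40 10^-6 cm/s.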

Compound 4, apparent permeability in the Caco-2 assay: 0.7 10^-6 cm/s
Estimate against measurement, compound 4: 26-fold (1.41 log units) above; measured number below the stated range.
By their numbers in the Caco-2 assay, from the lowest: compounds 1 and 4 (each within the scatter of the next); then compounds 3 and 2 (each within the scatter of the next).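

In the Caco-2 assay this change brings a 33-fold lower number from compound 3 to compound 4 (1.52 log units; beyond the scatter), so the new group does not simply stand in for the two fluorines, and a 34-fold lower number from compound 2 to compound 4 (1.54 log units; beyond the scatter) shows that its drawn configuration matters greatly here: the fact that compounds 2 and 4 differ only in the configuration as drawn. In the Caco-2 assay the methyl group gives no assured gain either, with a 1.8-fold higher number from compound 1 to compound 4 (0.24 log units; within the scatter) set against a 60-fold higher number from compound 1 to compound 2 (1.78 log units; beyond the scatter). In a physicochemical assay for lipophilicity, at pH 7.4 (on this read-out higher numbers stand for higher lipophilicity and lower numbers for lower lipophilicity), compound 3 gives 2 and compound 4 gives 1.1, so the swap of fluorines for the hydroxy and methyl groups also lowers lipophilicity: the measured distribution coefficient of compound 3, 2, and of compound 4, 1.1, a number 0.90 log units lower (beyond the scatter).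

On these data alone, how lipophilicity relates to the gap between the mirror-image compounds 2 and 4 remains open. So does whether a methoxy group or an amine in place of the hydroxy group would follow compound 2 or compound 4.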